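Replacing Bromo with Acetyl on Compound 3

A few compounds are considered here, and "the series" means these few. Any claim that something is new, unique, unknown or untested is made for them only; others in the source may bear on it.

In a functional assay (Nicotiana tabacum) (on this read-out lower numbers stand for stronger inhibition and higher numbers for weaker inhibition), compound 1 (`CCCNc1nc(SC)nc2ncccc12`) gives 270 nM and compound 2 (`CCCCC(CC)CNc1nc(SC)nc2ncccc12`) gives 15900 nM on the same core. Within the data shown here, the only measured single change is a 59-fold higher number from compound 1 to compound 2 (1.77 log units; beyond the scatter) with 1-ethylpentyl in place of ethyl on a saturated chain carbon. Compound 3 (`CSc1nc(Nc2ccc(Br)cc2)c2cccnc2n1`) gives 5750 nM as the second highest of the three numbers, above compound 1 and below compound 2.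

Compound 4 (`CSc1nc(Nc2ccc(C(C)=O)cc2)c2cccnc2n1`) has acetyl in place of bromo on an aromatic carbon, para to a large group. The measured step lies on the saturated chain, not on this aromatic carbon, so it shows that single changes can matter here but gives no size or direction for this swap. No shift beyond the scatter is therefore expected in this assay, and the estimated step is a 1.2-fold higher number from compound 3 to compound 4 (0.09 log units; within the scatter) with wide uncertainty. For compound 4 the estimate is 7000 nM with an expected range from 2000 nM to 25000 nM in this read-out.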

Compound 4, half-maximal inhibitory concentration: 8960 nM
Compound 4: the middle estimate sits 1.3-fold (0.11 log units) below what was measured; the range from low to high includes it.
By their numbers in this assay, from the lowest: compound 1; then compounds 3, 4 and 2 (each within the scatter of the next, the first and the last beyond it).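

In this assay, among these compounds, a 1.6-fold higher number from compound 3 to compound 4 (0.19 log units; within the scatter) gives the only measured step on this aromatic carbon, para to a large group, and it lies within the scatter. Acetyl brings three heavy atoms, a double bond outside the aromatic rings and a hydrogen-bond acceptor in place of the single atom of bromo, yet the read-out does not separate the two groups, unlike the large step on the saturated chain, a 59-fold higher number from compound 1 to compound 2 (1.77 log units; beyond the scatter). Nothing measured here explains this result or ties it to a property of either group.

Going by these compounds, only bromo and acetyl are seen on this carbon, so it remains open whether an amine or a carboxylic acid there would shift the number beyond the scatter. On these data alone, it is equally open whether a longer chain in place of acetyl would leave the number within the scatter of compound 3.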